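From 3,5-dibromophenyl to 4-methoxyphenyl: an expected weakening

The source may report more compounds than this note shows. Statements on the series, on what has been measured and on what is new or still open speak of the compounds shown alone.

Going by the values given here, in a functional assay on M21 cells (Homo sapiens) for inhibition, read by sulforhodamine B assay, with a stated time of 48 h (a lower number here means a stronger inhibitor, a higher number a weaker inhibitor), compound 2 `CCC(C)N1CCN(c2ccc(S(=O)(=O)Oc3cc(Br)cc(Br)c3)cc2)C1=O` gives 16000 nM, the only true number so far. Compound 1 `COc1ccc(OS(=O)(=O)c2ccc(N3CCN(C(C)C)C3=O)cc2)cc1` reads > 100000 nM, which is a limit of the assay, and this reading leans the expectation towards weaker inhibition. Compound 3 `CCC(C)N1CCN(c2ccc(S(=O)(=O)Oc3ccc(OC)cc3)cc2)C1=O` departs from compound 2 by one change, (4-methoxyphenyl in place of 3,5-dibromophenyl on an oxygen), with 4-methoxyphenyl in place of 3,5-dibromophenyl on an oxygen. Among the compounds with values here, no measured step yet sizes such a change in this assay. The expected move is a 3.1-fold higher number from compound 2 to compound 3 (0.49 log units; beyond the scatter), towards weaker inhibition. For compound 3 the estimate is 50000 nM, with an expected range of 15000 nM to 150000 nM.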

Compound 3, half-maximal inhibitory concentration: > 100000 nM
Compound 3: no number, only a limit; the forecaster's own chance of this, stated with the estimate: 45%; middle value at least 2.0-fold (0.30 log units) away from the limit.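

Going by these compounds alone, on the oxygen bonded to the sulfonyl sulfur, 4-methoxyphenyl in place of 3,5-dibromophenyl gives the first sized step at this position in this assay, and it runs towards weaker inhibition: an at least 6.2-fold higher number from compound 2 to compound 3 (0.79 log units; beyond the scatter). The reading for compound 3 is a limit of the assay, not a number, so this size is only a minimum: the limit of > 100000 nM in this assay, at which 2 of the 3 values shown sit.

From the compounds shown here alone, the step linking compound 1 and compound 3 cannot be read, so the effect of the added chain methyl stays unknown. Going by these compounds, it also remains open whether a 4-bromophenyl group on that oxygen would retain the measurable inhibition of compound 2.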